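A few compounds are considered here, and "the series" means these few. Any claim that something is new, unique, unknown or untested is made for them only; others in the source may bear on it.

Going by the values given here, in a functional assay on NCI-H322M cells (Homo sapiens) for inhibition, read by sulforhodamine B assay, with a stated time of 48 h (a lower number here means a stronger inhibitor of growth, a higher number a weaker inhibitor of growth), compound 1 `Nc1cc(N)c2nc(-c3ccccc3)c(Oc3ccc(Cl)c(Cl)c3)nc2c1` gives 58900 nM, the only plain number among the three measured compounds. Compound 2 `CCOC(=O)[C@H](CCC(=O)O)NC(=O)c1ccc(CNc2nc3cc(N)cc(N)c3nc2-c2ccccc2)cc1` stops at a limit of this assay, < 100000 nM. Compound 3 `CCOC(=O)[C@H](CCC(=O)O)NC(=O)c1ccc(Sc2nc3cc(N)cc(N)c3nc2-c2ccccc2)cc1` also reaches only a limit, < 100000 nM. Compound 1 thus stands alone with a measured value, while the limit of < 100000 nM in this assay, at which 2 of the 3 values shown sit, covers the other two. Compound 4 `Nc1cc(N)c2nc(-c3ccccc3)c(NCc3ccc(F)cc3)nc2c1` has not yet been measured; it differs from compound 1 in a single place, ((4-fluorobenzyl)amino in place of 3,4-dichlorophenoxy on an aromatic carbon), that is, (4-fluorobenzyl)amino in place of 3,4-dichlorophenoxy on an aromatic carbon. Among the compounds with values here, no measured pair shows this change, so there is no step to lean on. The step that the estimate means is expected to be small, a 1.5-fold lower number from compound 1 to compound 4 (0.17 log units; within the scatter), not clearly beyond the scatter. Compound 4 is estimated at 40000 nM, with a range from 10000 nM to 100000 nM.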

Compound 4, concentration for total growth inhibition: 11500 nM
Estimate against measurement, compound 4: 3.5-fold (0.54 log units) above; the range from low to high includes it.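

In this assay, going by these compounds alone, putting (4-fluorobenzyl)amino in place of 3,4-dichlorophenoxy gives a 5.1-fold lower number from compound 1 to compound 4 (0.71 log units; beyond the scatter), the first readable step. This shows that growth inhibition responds to the group on this aromatic carbon next to the ring nitrogen. The entering group brings a hydrogen-bond donor that the leaving group lacks, but nothing measured here accounts for the step. As far as these compounds go, whether the linking nitrogen, the extra carbon or the halogens matter remains open. A 4-fluorobenzyloxy group or a plain benzylamino group would help separate these.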